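This account rests on a few compounds, and the source may have more. Where it says the series, first, only, none or still open, it means among the compounds named here.

Measured in an assay on CHO cells for displacement of a labelled ligand from adenosine receptor A1 (Homo sapiens), read by scintillation counting; a lower number here means a stronger inhibitor, a higher number a weaker inhibitor:
compound 1, `Nc1nc(Cc2ccccc2Cl)nc2cn(-c3ccccc3)nc12`: 155 nM
compound 2, `Nc1nc(Cc2cccc(O)c2)nc2cn(-c3ccccc3)nc12`: 312 nM
compound 3, `Nc1nc(CCc2ccc(O)cc2)nc2cn(-c3ccccc3)nc12`: 420 nM

Among these three, compound 3 has the highest number; the gap to compound 2 is within the scatter, while compound 1 sits further off, with a 2.7-fold higher number from compound 1 to compound 3 (0.43 log units; beyond the scatter). Compound 4 is `COc1ccc(CCCc2nc(N)c3nn(-c4ccccc4)cc3n2)cc1`, and it differs from compound 3 in one place: 4-methoxybenzyl in place of 4-hydroxyphenyl on a saturated chain carbon, two bonds along the chain from an aromatic carbon. The nearest measured step is a 1.3-fold higher number from compound 2 to compound 3 (0.13 log units; within the scatter), where the side chain grew by one carbon and the hydroxyl moved, with no change beyond the scatter. Going by the values given here, no measured step removes a hydroxyl donor or adds a methoxy group, so the change is only partly covered. An expected step of a 1.1-fold higher number from compound 3 to compound 4 (0.03 log units; within the scatter) seems reasonable, so compound 4 is estimated at 450 nM, within 150 nM to 1300 nM.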

Compound 4, inhibition constant: 16 nM
Compound 4: the middle estimate sits 28-fold (1.45 log units) above what was measured; the measured number lies below the stated range.
By their numbers in this assay, from the lowest: compound 4; then compounds 1, 2 and 3 (each within the scatter of the next, the first and the last beyond it).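

In this assay, going by these compounds alone, this position turns out to be far more sensitive than the earlier compounds suggested: the swap to 4-methoxybenzyl gives a 26-fold lower number from compound 3 to compound 4 (1.42 log units; beyond the scatter), whereas the earlier steps were modest or within the scatter. Within the data shown here, the entering group has 0 hydrogen-bond donors and a longer chain, and the change is the first here to give a large drop in the number. Nothing available explains this gain.

As far as these compounds go, the longer chain and the methoxy group arrive together, so the share of each remains open. Also open, from the compounds shown here alone, is how an ethoxy group, an amine or a still longer chain would behave here.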